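The source may report more compounds than this note shows. Statements on the series, on what has been measured and on what is new or still open speak of the compounds shown alone.

Working notes on the series, read in a functional assay on HL-60 cells (Homo sapiens) for antiproliferative activity, with a stated time of 24 h; on this read-out higher numbers stand for weaker inhibition and lower numbers for stronger inhibition. The unsubstituted compound 1 `NC(=O)c1c(NC(=O)c2ccccc2Cl)sc2c1CCNC2` gives 18600 nM. Compound 2 `Cc1ccccc1CN1CCc2c(sc(NC(=O)c3ccccc3Cl)c2C(N)=O)C1`, carrying 2-methylbenzyl, reads > 50000 nM, and this value is a limit of the assay. Among the measured compounds shown here, compound 3 `NC(=O)c1c(NC(=O)c2ccccc2Cl)sc2c1CCN(Cc1ccccc1Cl)C2`, carrying 2-chlorobenzyl, gives 2900 nM, the lowest number so far.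

Compound 4 `NC(=O)c1c(NC(=O)c2ccccc2Cl)sc2c1CCN(Cc1c(Cl)cccc1Cl)C2` differs from compound 3 by chloro in place of hydrogen on an aromatic carbon, taking 2-chlorobenzyl to 2,6-dichlorobenzyl. For the measured compounds named here, no measured step adds a second chloro, so the evidence is indirect. Two steps favour chloro on this ring: a 6.4-fold lower number from compound 1 to compound 3 (0.81 log units; beyond the scatter), and the large at least 17-fold lower number from compound 2 to compound 3 (1.23 log units; beyond the scatter). Substitution at the ring nitrogen is not reliably favourable, since compound 2 goes against the trend with an at least 2.6-fold higher number from compound 1 to compound 2 (0.42 log units; beyond the scatter). A small move to a lower number in this assay is therefore expected, possibly not beyond the scatter. The expected step is a 1.6-fold lower number from compound 3 to compound 4 (0.21 log units; within the scatter). The estimated value for compound 4 is 1800 nM. The expected range for compound 4 runs from 600 nM to 7000 nM.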

Compound 4, half-maximal inhibitory concentration: 4850 nM
Compound 4: the middle estimate sits 2.7-fold (0.43 log units) below what was measured, and the stated range covers the measured number.
By their numbers in this assay, from the lowest: compounds 3 and 4 (each within the scatter of the next); then compound 1. At a limit, above all of these: compound 2.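

In this assay, a second chloro on the six-membered aromatic ring makes no change beyond the scatter, with a 1.7-fold higher number from compound 3 to compound 4 (0.22 log units; within the scatter), so 2-chlorobenzyl and 2,6-dichlorobenzyl cannot be told apart at this position. Compound 4 keeps a lower number than the unsubstituted compound, with a 3.8-fold lower number from compound 1 to compound 4 (0.58 log units; beyond the scatter), so the advantage over hydrogen on the amine nitrogen now holds for both chloro-bearing benzyl groups, with compound 2 going against it. The separation from 2-methylbenzyl also remains, with an at least 10-fold lower number from compound 2 to compound 4 (1.01 log units; beyond the scatter), but this step is only a bound, since compound 2 is read at a limit: the limit of > 50000 nM in this assay, at which 1 of the 4 values shown sits.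

On these data alone, whether fluoro or methoxy on this aromatic carbon would track the chloro compounds or compound 2 remains open. Also open, as far as these compounds go, is whether a longer chain between the amine nitrogen and the aromatic ring would preserve the numbers of compounds 3 and 4.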